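Turning the amide around on compound 2's pyridine

The source may report more compounds than this note shows. Statements on the series, on what has been measured and on what is new or still open speak of the compounds shown alone.

Of the compounds shown here, three share one core and have been tested in a functional assay on K562 cells (Homo sapiens) for inhibition, read by MTT assay, with a stated time of 48 h; on this read-out higher numbers stand for weaker inhibition and lower numbers for stronger inhibition. Compound 1 `CC(C)(C)OC(=O)N1C[C@@H](n2cc(-c3ccc(N)nc3)nn2)C[C@H]1C(=O)Nc1ccc(Cl)c(C(F)(F)F)c1` gives 4710 nM. Compound 2 `O=C(Nc1ccc(-c2cn([C@@H]3CN[C@H](C(=O)Nc4ccc(Cl)c(C(F)(F)F)c4)C3)nn2)cn1)C1CC1` gives 8770 nM, the highest number of the three; compound 1 lies within the usual scatter of it, while compound 3 `C=CC(=O)Nc1ccc(-c2cn([C@@H]3CN[C@H](C(=O)Nc4ccc(Cl)c(C(F)(F)F)c4)C3)nn2)cn1`, which gives 3860 nM, lies beyond it.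

For the measured compounds named here, the single measured step that changes only one place is a 2.3-fold lower number from compound 2 to compound 3 (0.36 log units; beyond the scatter). It alters the group on the carbonyl carbon and leaves the rest of the molecule untouched.

Compound 4 `O=C(NC1CC1)c1cncc(-c2cn([C@@H]3CN[C@H](C(=O)Nc4ccc(Cl)c(C(F)(F)F)c4)C3)nn2)c1` differs from compound 2 in another way: 5-(cyclopropylcarbamoyl)pyridin-3-yl in place of 6-((cyclopropylcarbonyl)amino)pyridin-3-yl on an aromatic carbon. The same atoms are present, joined differently, so the amide is reversed and the pyridine is attached through a different ring carbon.

Going by the values given here, no measured step bears on this kind of change; the step from compound 2 to compound 3 concerns a different part of the molecule. With nothing to build on, no movement beyond the scatter is expected, so the step from compound 2 to compound 4 is estimated as a 1.0-fold higher number from compound 2 to compound 4 (0.01 log units; within the scatter). Compound 4 is therefore expected to give about 9000 nM, with a likely range from 3500 nM to 23000 nM.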

Compound 4, half-maximal inhibitory concentration: 820 nM
Compound 4: middle estimate off by 11-fold (1.04 log units), on the high side, outside the stated range (below it).
By their numbers in this assay, from the lowest: compound 4; then compounds 3, 1 and 2 (each within the scatter of the next, the first and the last beyond it).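

In this assay this aromatic carbon on the shared core proves sensitive to how the same atoms are joined: there is an 11-fold lower number from compound 2 to compound 4 (1.03 log units; beyond the scatter) even though the leaving and entering groups have identical counts of atoms, rings, hydrogen-bond donors and hydrogen-bond acceptors. The lower number is not confined to the comparison with the cyclopropyl amide, since there is also a 4.7-fold lower number from compound 3 to compound 4 (0.67 log units; beyond the scatter) when the vinyl compound is the starting point, so among these compounds the 5-(cyclopropylcarbamoyl)pyridin-3-yl group gives the strongest inhibition at this position. Nothing available here explains why rearranging the same atoms has this effect.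

This single change both reverses the amide and alters the ring carbon through which the pyridine is attached, and the compounds shown cannot say how much of the step belongs to each of the two. They also leave open whether the lower number would survive replacing the cyclopropyl group on the amide nitrogen with a longer chain, or replacing the whole cyclopropylcarbamoyl group with a carboxylic acid.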